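Sulfonamide benzoxazoles against HSP60/HSP10: a core rearrangement

The source may hold more compounds than are shown below. What is called first, only, known or untested is meant among the compounds shown, and "the series" means these compounds.

Compound 1, `O=S(=O)(Nc1ccc2oc(-c3ccccc3)nc2c1)c1ccc(Cl)c(Cl)c1`, gives a limit in an assay on cells for inhibition of HSP60/HSP10 (Homo sapiens), with a stated time of 60 min; a higher number here means a weaker inhibitor, a lower number a stronger inhibitor: > 100000 nM.
Compound 2, `Cc1cccc(S(=O)(=O)Nc2ccc3oc(-c4ccccc4)nc3c2)c1`, gives a limit in this assay: > 100000 nM.
Compound 3, `O=S(=O)(Nc1ccc(-c2nc3ccccc3o2)cc1)c1ccc(Cl)c(Cl)c1`, gives in this assay a value of 25000 nM.

Compounds 1 and 2 share a core, and the change between them is 3-methylphenyl in place of 3,4-dichlorophenyl on a sulfonyl sulfur. Both sit at a limit, so the step that the two limits leave unreadable from compound 1 to compound 2 cannot be read; the reason lies in the limit of > 100000 nM in this assay, at which 2 of the 3 values shown sit. Compound 3 has the same atoms as compound 1 joined differently, and the difference between the two cores is not broken down here. Within the data shown here, compound 3 is the only member of the set with a number rather than a limit.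

Compound 4, `Cc1cccc(S(=O)(=O)Nc2ccc(-c3nc4ccccc4o3)cc2)c1`, has not been measured. It differs from compound 3 by 3-methylphenyl in place of 3,4-dichlorophenyl on a sulfonyl sulfur, the same change as from compound 1 to compound 2. That earlier step offers no size, since both of its ends are limits. Compound 3 itself is already weak, so compound 4 is expected to move by a 2.0-fold higher number from compound 3 to compound 4 (0.30 log units; within the scatter) in this assay, resting only on compound 3 with 25000 nM as the starting point. Compound 4 is therefore estimated at 50000 nM, between 12000 nM and 200000 nM.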

Compound 4, half-maximal inhibitory concentration: > 100000 nM
Compound 4 gave a limit, no number; the forecaster's own chance of this, stated with the estimate: 40%; middle value at least 2.0-fold (0.30 log units) away from the limit.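

On the core of compound 3, 3-methylphenyl in place of 3,4-dichlorophenyl on a sulfonyl sulfur gives, in this assay, an at least 4.0-fold higher number from compound 3 to compound 4 (0.60 log units; beyond the scatter). The true size of this step may be larger, because it ends on a limit and not on a number: the limit of > 100000 nM in this assay, at which 3 of the 4 values shown sit. The same change on the core of compound 1 has limits at both ends and cannot be read, so the result shows a clear loss on one core only and does not show whether the step has the same size on both.

Among the compounds shown, only compound 3 gives a number in this assay, and only two groups appear on the sulfonyl sulfur. Still open, going by these compounds, is what 4-chlorophenyl, with a single chlorine, would give on the core of compound 3, and whether a phenyl ring carrying an amine or a carboxylic acid at that place would give a number at all.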